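One Added Methoxy on Compound 2

The source may report more compounds than this note shows. Statements on the series, on what has been measured and on what is new or still open speak of the compounds shown alone.

- compound 1 `COc1cccc(/C=C/C(=O)c2ccc(N)cc2)c1` at 21000 nM
- compound 2 `COc1ccccc1/C=C/C(=O)c1ccc(N)cc1` at 8300 nM

Both numbers come from a functional assay on MOLT-4 cells (Homo sapiens) for antiproliferative activity, with a stated time of 48 h (a higher number here means a weaker inhibitor, a lower number a stronger inhibitor), and are all that has been measured so far. Compound 2 holds the lower of the two numbers, and the gap up to compound 1 lies beyond the scatter, so compound 2 is the stronger inhibitor of this pair.

The next structure is compound 3 `COc1cccc(/C=C/C(=O)c2ccc(N)cc2)c1OC` and it arises from compound 2 through one change. That change, methoxy in place of hydrogen on an aromatic carbon in count, is methoxy in place of hydrogen on an aromatic carbon, ortho to a methoxy group and meta to a large group.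

Within the data shown here, no measured pair here differs in one place only, so nothing yet shows directly what such an addition does. Among the measured compounds shown here, the only guide is the gap between compound 1 at 21000 nM and compound 2 at 8300 nM in this assay alone. The expected change is a 1.3-fold higher number from compound 2 to compound 3 (0.12 log units; within the scatter) as a small move toward a higher number, not beyond the scatter. The estimated value for compound 3 is 11000 nM within an expected range from 4000 nM to 30000 nM here.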

Compound 3, half-maximal inhibitory concentration: 8500 nM
The estimate for compound 3 lay 1.3-fold (0.11 log units) above the measured number, within the range that was stated.
By their numbers in this assay, from the lowest: compounds 2 and 3 (each within the scatter of the next); then compound 1.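

In this assay a methoxy in place of hydrogen on this aromatic carbon, ortho to a methoxy group and meta to a large group, gives a 1.0-fold higher number from compound 2 to compound 3 (0.01 log units; within the scatter) so this position takes the added group with no measurable gain or loss from the starting number. Among these compounds, the same kind of change read along the other available pair gives a 2.5-fold lower number from compound 1 to compound 3 (0.39 log units; beyond the scatter) and this is the first direct sign that adding a methoxy to the ring does not have one fixed effect, since a step of this type can stay within the scatter on one compound and pass beyond it on another. Nothing measured here gives a reason for the difference between these two steps.

Going by these compounds, whether a fluorine, a hydroxyl or an ethoxy group on this same aromatic carbon would also leave the number in place remains open. Also open, on these data alone, is whether the same two steps would keep their sizes with an acetyl group or a carboxylic acid in place of the amino group on the shared core.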